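The source may report more compounds than this note shows. Statements on the series, on what has been measured and on what is new or still open speak of the compounds shown alone.

Measured compounds:
compound 1, `O=C(CSc1nncnc1-c1cccc2ccccc12)Nc1ccccc1Br`: 87000 nM
compound 2, `COC(=O)c1sccc1NC(=O)CSc1nncnc1-c1ccccc1Cl`: 105000 nM
compound 3, `O=C(CSc1nncnc1-c1ccccc1Cl)c1ccc(Cl)c(Cl)c1`: 33000 nM

Of the compounds shown here, three have been tested in an ADME assay on MT4 cells (Homo sapiens) for cytotoxicity, read by MTT assay; on this read-out higher numbers stand for lower toxicity in this test and lower numbers for higher toxicity in this test. Compound 1 gives 87000 nM, the second highest of the three numbers. Compound 2, with 105000 nM, lies within the usual scatter of compound 1, so the two cannot be told apart on this read-out. Compound 3, with 33000 nM, sits clearly lower than compound 1, a gap beyond the scatter.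

Compound 4 `O=C(CSc1nncnc1-c1cccc2ccccc12)N1CCc2ccccc2C1` has not yet been measured. It differs from compound 1 in one place: 1,2,3,4-tetrahydroisoquinolin-2-yl in place of (2-bromophenyl)amino on a carbonyl carbon. Going by the values given here, no measured pair differing in just one place exists here, so nothing measured shows how such a change moves the half-maximal cytotoxic concentration in this assay. The three measured numbers span a modest range and the shared core stays untouched. The expected step is a 1.1-fold lower number from compound 1 to compound 4 (0.04 log units; within the scatter), small, in no settled direction, and not beyond the scatter. For compound 4 the expected value in this assay is 80000 nM, with a likely range from 30000 nM to 200000 nM.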

Compound 4, half-maximal cytotoxic concentration: 13000 nM
Compound 4: middle estimate off by 6.2-fold (0.79 log units), on the high side, outside the stated range (below it).
By their numbers in this assay, from the lowest: compound 4; then compound 3; then compounds 1 and 2 (each within the scatter of the next).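

Going by these compounds alone, this is the first measured change at the group on the carbonyl carbon, and it shows that this position can move the number in this assay while the shared core stays the same. Putting 1,2,3,4-tetrahydroisoquinolin-2-yl in place of (2-bromophenyl)amino gives a 6.7-fold lower number from compound 1 to compound 4 (0.83 log units; beyond the scatter) and so a higher toxicity in this test. The swap removes the amide hydrogen and adds a non-aromatic ring at once, and no measurement here explains the step.

From the compounds shown here alone, it stays open which of these two differences goes with the lower number: piperidin-1-yl on the same carbonyl carbon would also lack the amide hydrogen but carry no aromatic ring, while benzylamino would keep both. Going by these compounds, whether the same swap acts alike on a 2-chlorophenyl version of the core is also open.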